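A Methyl on the Pyridine of a Receptor Modulator

The compounds below may be only part of what the source reports. "The series", "measured", "known", "first", "only" and "open" are said of these compounds alone.

Among the measured compounds shown here, compound 2 `CC(C)CCn1ccc(-c2ccc(Oc3ccncc3)cc2)c(C#N)c1=O` gives 245% in a functional assay on CHO cells for positive allosteric modulation of metabotropic glutamate receptor 2 (Homo sapiens), read by scintillation counting and GTPgammaS binding, with a stated time of 30 min (a lower number here means a smaller maximal response, a higher number a larger maximal response), the higher of the two numbers known, since compound 1 `CC(C)CCn1ccc(-c2ccccc2)c(C#N)c1=O` gives 117%. That difference, a number 128 percentage points higher from compound 1 to compound 2 (beyond the scatter), arose from (pyridin-4-yl)oxy in place of hydrogen on an aromatic carbon. Compound 3 `Cc1cc(Oc2ccc(-c3ccn(CCC(C)C)c(=O)c3C#N)cc2)ccn1` differs from compound 2 by methyl in place of hydrogen on an aromatic carbon. For the measured compounds named here, no measured step alters the pyridin-4-yl group itself; the one known step concerns the arrival of that group rather than a methyl on it, so it bears only loosely. The expected step is therefore no change at the digits printed from compound 2 to compound 3 (within the scatter), nothing beyond the scatter. The estimate for compound 3 is 245%, with a range from 180% to 310%.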

Compound 3, largest response reached (Emax), in percent of the reference or control that the assay uses: 266%
Beside the measured number, compound 3's estimate is 21 percentage points below it; the measured number falls inside the stated range.
By their numbers in this assay, from the lowest: compound 1; then compound 2; then compound 3.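

The change from pyridin-4-yl to 2-methylpyridin-4-yl, with the methyl next to the ring nitrogen, gives in this assay a number 21 percentage points higher from compound 2 to compound 3 (beyond the scatter), so this aromatic carbon accepts a methyl and the maximal response still rises. Measured from the core of compound 1, the whole (2-methylpyridin-4-yl)oxy group gives a number 149 percentage points higher from compound 1 to compound 3 (beyond the scatter), and most of that gain was already present without the methyl. From the compounds shown here alone, whether an ethyl, a methoxy or an amine at this same carbon would carry the response further stays open. Nothing available here explains the added rise.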